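Swapping the aryl group on the hydrazone carbon of compound 1

This account rests on a few compounds, and the source may have more. Where it says the series, first, only, none or still open, it means among the compounds named here.

Compound 1 `O=C(N/N=C/c1cccc([N+](=O)[O-])c1)Nc1ccc(Oc2ccnc3[nH]ccc23)c(F)c1` carries a 3-nitrophenyl group on a carbon with a double bond to nitrogen, attached through a semicarbazide to a fluorinated diaryl ether core. In a functional assay on A549 cells (Homo sapiens) for antiproliferative activity, read by MTT assay, with a stated time of 72 h (on this read-out higher numbers stand for weaker inhibition and lower numbers for stronger inhibition), compound 1 gives 3640 nM, the second highest of the three numbers measured. Compound 2 `O=C(N/N=C/c1ccc(Cl)c(Cl)c1)Nc1ccc(Oc2ccnc3[nH]ccc23)c(F)c1` gives 2650 nM, a step of a 1.4-fold lower number from compound 1 to compound 2 (0.14 log units; within the scatter). Compound 3 `COc1cc(/C=N/NC(=O)Nc2ccc(Oc3ccnc4[nH]ccc34)c(F)c2)cc(OC)c1OC` gives 34100 nM, the weakest of the set and well beyond the scatter from compound 1.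

Compound 4 `O=C(N/N=C/c1cc(Br)c(O)c(Br)c1)Nc1ccc(Oc2ccnc3[nH]ccc23)c(F)c1` has not yet been measured. It differs from compound 1 in one place: 3,5-dibromo-4-hydroxyphenyl in place of 3-nitrophenyl on a carbon with a double bond to nitrogen. Among the measured compounds shown here, the only measured step at the same position, from compound 1 to compound 2, was small and within the scatter, while the trimethoxyphenyl of compound 3 brought a much larger loss. A halogenated phenyl group thus bears most directly on the change, and the step of a 1.2-fold lower number from compound 1 to compound 4 (0.08 log units; within the scatter) is expected to be small. Compound 4 is therefore estimated at 3000 nM, with a range from 900 nM to 10000 nM.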

Compound 4, half-maximal inhibitory concentration: 16200 nM
Beside the measured number, compound 4's estimate is 5.4-fold (0.73 log units) below it, outside the stated range (above it).
By their numbers in this assay, from the lowest: compounds 2 and 1 (each within the scatter of the next); then compound 4; then compound 3.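

In this assay, a halogenated phenyl group does not by itself hold this position near compound 1: the 3,5-dibromo-4-hydroxyphenyl group gives a 4.5-fold higher number from compound 1 to compound 4 (0.65 log units; beyond the scatter), and a 6.1-fold higher number from compound 2 to compound 4 (0.79 log units; beyond the scatter). The earlier compounds had shown a change beyond the scatter only with the trimethoxyphenyl group of compound 3, so the position now also separates two halogen-bearing phenyl groups, the 3,4-dichlorophenyl of compound 2 and the 3,5-dibromo-4-hydroxyphenyl of compound 4. No measurement here bears on why this step arises.

The bromine atoms and the hydroxyl group enter together, so the compounds shown cannot assign the step to either one. On these data alone, a phenyl group carrying only the hydroxyl, only the two bromines, or an amine at this position remains open.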